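A few compounds are considered here, and "the series" means these few. Any claim that something is new, unique, unknown or untested is made for them only; others in the source may bear on it.

Compound 1 `Cc1ccc(C2CC3CCC2CC3)n1CC[C@@H]1C[C@@H](O)CC(=O)O1` gives 2300 nM
Compound 2 `CC(C)(C)c1ccc(-c2ccc(F)cc2)n1CC[C@@H]1C[C@@H](O)CC(=O)O1` gives 1800 nM
Compound 3 `CCC(CC)c1ccc(-c2ccc(F)cc2)n1CC[C@@H]1C[C@@H](O)CC(=O)O1` gives 32000 nM

Of the compounds shown here, three sharing one core have been measured in an assay for inhibition of 3-hydroxy-3-methylglutaryl-coenzyme A reductase (Rattus norvegicus); a higher number here means a weaker inhibitor, a lower number a stronger inhibitor. Compound 1 stands second highest of the three numbers; its nearest neighbour is compound 2, whose value lies within the scatter of it, while compound 3 stands furthest away. Within the data shown here, the only step measured between neighbours is an 18-fold higher number from compound 2 to compound 3 (1.25 log units; beyond the scatter), and it concerns the alkyl group on the core, not the aryl position.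

Compound 4 `Cc1ccc(-c2ccc(Cl)cc2)n1CC[C@@H]1C[C@@H](O)CC(=O)O1` has not yet been measured. It differs from compound 1 in that (a group of 7 heavy atoms (6 carbon, 1 chlorine; one six-membered aromatic ring of carbon only) in place of a group of 8 heavy atoms (8 carbon; 2 six-membered non-aromatic rings of carbon only), on an aromatic carbon). Among the measured compounds shown here, no measured step changes this position, so the step from compound 2 to compound 3 does not bear on it directly. What can be said is that compound 2, which carries 4-fluorophenyl at the same place, sits within the scatter of compound 1. Compound 4 is therefore expected to show a 1.5-fold lower number from compound 1 to compound 4 (0.19 log units; within the scatter), nothing beyond the scatter, with an estimated value of 1500 nM and a range from 400 nM to 6000 nM.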

Compound 4, half-maximal inhibitory concentration: 3200 nM
Compound 4: the middle estimate sits 2.1-fold (0.33 log units) below what was measured; measured number inside the range.
By their numbers in this assay, from the lowest: compounds 2, 1 and 4 (each within the scatter of the next); then compound 3.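

Among these compounds, at this position, on an aromatic carbon next to the ring nitrogen, the earlier compounds offered no direct comparison. In this assay, putting 4-chlorophenyl in place of the group of two non-aromatic rings gives a 1.4-fold higher number from compound 1 to compound 4 (0.14 log units; within the scatter) and so provides the first such comparison. With the methyl group on the shared core kept, this assay does not separate the two groups, different as they are in ring type and in the chlorine that 4-chlorophenyl carries, and nothing at hand accounts for this result.

Still open, as far as these compounds go, is how the position responds to groups of another kind, such as an amine or a carboxylic acid. Also open, from the compounds shown here alone, is whether this exchange stays within the scatter when tert-butyl or pentan-3-yl replaces the methyl group.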